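A few compounds are considered here, and "the series" means these few. Any claim that something is new, unique, unknown or untested is made for them only; others in the source may bear on it.

Measured so far:

Compound 1, `Cc1ccc(-c2nn(-c3ccccc3)cc2-c2nc3ccccc3n2S(=O)(=O)c2ccc(Cl)cc2)cc1`: 4060 nM
Compound 2, `Cc1ccc(-c2nn(-c3ccccc3)cc2-c2nc3ccccc3n2S(=O)(=O)c2ccc(Br)cc2)cc1`: 2340 nM
Compound 3, `O=S(=O)(c1ccc(Cl)cc1)n1c(-c2cn(-c3ccccc3)nc2-c2ccc(F)cc2)nc2ccccc21`: 3450 nM

All three were tested in a functional assay on HeLa cells (Homo sapiens) for antiproliferative activity, read by MTT assay, with a stated time of 24 h; a higher number here means a weaker inhibitor, a lower number a stronger inhibitor. Compound 1 gives 4060 nM, compound 2 gives 2340 nM and compound 3 gives 3450 nM. The three numbers lie close together, and each step between them is said to fall within the ordinary scatter of such measurements, so none of the three can be called stronger or weaker than another on this evidence.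

Compound 2 differs from compound 1 in one place: bromo in place of chloro on an aromatic carbon. This change gave a 1.7-fold lower number from compound 1 to compound 2 (0.24 log units; within the scatter). Compound 3 differs from compound 1 in another place: fluoro in place of methyl on an aromatic carbon, a step of a 1.2-fold lower number from compound 1 to compound 3 (0.07 log units; within the scatter).

The compound still to be measured is compound 4, `O=S(=O)(c1ccc(Br)cc1)n1c(-c2cn(-c3ccccc3)nc2-c2ccc(F)cc2)nc2ccccc21`. It stands to compound 3 exactly as compound 2 stands to compound 1: bromo in place of chloro on an aromatic carbon. The surroundings of the change are described in the same words for both pairs, so this is the same change made on a different core, where the two cores differ as described for compound 3 against compound 1.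

Among the measured compounds shown here, with only one earlier example of this change, and that one within the scatter, the expectation for compound 4 is a step of about the same size as the earlier one, that is a 1.6-fold lower number from compound 3 to compound 4 (0.22 log units; within the scatter), resting on compound 1 and compound 2 and their step of a 1.7-fold lower number from compound 1 to compound 2 (0.24 log units; within the scatter). Compound 4 is therefore estimated at 2100 nM in this assay, with a likely range from 1000 nM to 4500 nM.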

Compound 4, half-maximal inhibitory concentration: 2040 nM
Compound 4: the middle estimate sits 1.0-fold (0.01 log units) above what was measured; low and high end bracket the measured number.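

In this assay, bromo in place of chloro gives a 1.7-fold lower number from compound 3 to compound 4 (0.23 log units; within the scatter), and this step matches the one seen on the other core: the same change on two cores in this assay, a 1.7-fold lower number (0.24 log units; within the scatter) from compound 1 to compound 2 and a 1.7-fold lower number (0.23 log units; within the scatter) from compound 3 to compound 4, 1.0-fold (0.01 log units) apart, within the scatter of two such steps

Read the other way around the same four compounds, fluoro in place of methyl gives a 1.1-fold lower number from compound 2 to compound 4 (0.06 log units; within the scatter), and this step also matches its earlier counterpart: the same change on two cores in this assay, a 1.2-fold lower number (0.07 log units; within the scatter) from compound 1 to compound 3 and a 1.1-fold lower number (0.06 log units; within the scatter) from compound 2 to compound 4, 1.0-fold (0.01 log units) apart, within the scatter of two such steps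

So each change gave a matching result on both cores, with no sign here that the core alters the outcome, but all of these steps lie within the scatter, so they do not show that either change truly shifts the number, and two pairs cannot show that the match would hold on other cores.

The compounds shown leave open what happens with groups other than chloro and bromo on the phenyl ring of the sulfonyl group, such as an amine, a methoxy group or a carboxylic acid, and with groups other than methyl and fluoro on the other phenyl ring, such as a longer chain. On these data alone, it also remains open whether any such group would give a step beyond the scatter, and whether steps of that size would then carry from one core to the other as these do.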